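A few compounds are considered here, and "the series" means these few. Any claim that something is new, unique, unknown or untested is made for them only; others in the source may bear on it.

Compound 1 `CCCN(CC1CCOCC1)c1c(CC)nn2c(-c3c(OC)cc(COC)cc3OC)cccc12` — 90 nM
Compound 2 `CCc1nn2c(-c3c(OC)cc(COC)cc3OC)cccc2c1N(CC1CCOCC1)CC1CC1` — 50 nM
Compound 3 `COCc1cc(OC)c(-c2cccc3c(N(CC4CCOCC4)CC4CC4)c(C#N)nn23)c(OC)c1` — 52 nM

In an assay on HEK293 cells for displacement of a labelled ligand from corticotropin-releasing factor receptor 1 (Homo sapiens), read by scintillation counting, with a stated time of 2 h (a higher number here means a weaker inhibitor, a lower number a stronger inhibitor), compound 2 gives the smallest of the three numbers, yet neither gap around it exceeds the scatter: a 1.8-fold lower number from compound 1 to compound 2 (0.26 log units; within the scatter) and a 1.0-fold higher number from compound 2 to compound 3 (0.02 log units; within the scatter). Compound 4 `CCOCc1cc(OC)c(-c2cccc3c(N(CC4CCOCC4)CC4CC4)c(CC)nn23)c(OC)c1` differs from compound 2 by methyl in place of hydrogen on a saturated chain carbon bound to an oxygen on a saturated carbon. Neither measured step touches this part of the molecule: one changes a chain carbon bound to a nitrogen on an aromatic ring, the other an aromatic carbon, and both stay within the scatter. Going by the values given here, no step therefore speaks for a shift beyond the scatter in this assay for compound 4. The step expected from this reasoning, a 1.1-fold higher number from compound 2 to compound 4 (0.04 log units; within the scatter), lies within the scatter. Compound 4 is estimated at 55 nM, with a range from 25 nM to 120 nM.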

Compound 4, half-maximal inhibitory concentration in the corticotropin-releasing factor receptor 1 assay: 49 nM
Beside the measured number, compound 4's estimate is 1.1-fold (0.05 log units) above it, within the range that was stated.
By their numbers in the corticotropin-releasing factor receptor 1 assay, from the lowest: compounds 4, 2, 3 and 1 (each within the scatter of the next).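

In the corticotropin-releasing factor receptor 1 assay the change from methoxymethyl to ethoxymethyl reads as a 1.0-fold lower number from compound 2 to compound 4 (0.01 log units; within the scatter), so this position accepts the added methyl without a step beyond the scatter. In a physicochemical assay for solubility, in phosphate buffer, measured as kinetic solubility (a higher number here means a more soluble compound, a lower number a less soluble compound), compound 2 gives 4800 nM and compound 4 gives 1400 nM. The same methyl therefore has a cost that the earlier compounds could not show, one that appears in solubility rather than in binding: the measured solubility of compound 2, 4800 nM, and of compound 4, 1400 nM, a 3.4-fold lower number (0.54 log units; beyond the scatter)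

What the compounds shown leave open is whether another group at this place, such as a hydroxyl or an amine on the chain, would hold the number in the corticotropin-releasing factor receptor 1 assay and also raise solubility.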